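Cyclohexyl to Hydrogen on the Ring Nitrogen: Cytotoxicity Outlook

A few compounds are considered here, and "the series" means these few. Any claim that something is new, unique, unknown or untested is made for them only; others in the source may bear on it.

Measured compounds:
compound 1 `CCC(=O)Nc1ccc(-c2nc3cc(C(F)(F)F)ccc3n2C2CCCCC2)cc1`. In an ADME assay on Vero cells (Chlorocebus sabaeus) for cytotoxicity (a higher number here means that more compound is tolerated, a lower number that less compound is tolerated), compound 1 gives > 100000 nM, which is a limit of the assay and not a number.
compound 2 `Nc1ccc(-c2nc3cc(Cl)c(Cl)cc3[nH]2)cc1`. In this assay compound 2 gives >= 100000 nM, again a limit of the assay.
compound 3 `COc1ccc(-c2nc3cc(C(F)(F)F)ccc3[nH]2)c(OC)c1`. In this assay compound 3 gives > 100000 nM, once more a limit of the assay.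

Compound 1 therefore stands at the limit of > 100000 nM in this assay, at which 2 of the 3 values shown sit, and only a limit is known for it. The remaining value sits at the limit of >= 100000 nM in this assay, at which 1 of the 3 values shown sits. Going by the values given here, none of the three compounds gives a number, so no step between measured compounds can be read, and nothing here separates the compounds from one another in this assay.

Compound 4 `CCC(=O)Nc1ccc(-c2nc3cc(C(F)(F)F)ccc3[nH]2)cc1` is the next compound to be measured. It differs from compound 1 by hydrogen in place of cyclohexyl on an aromatic nitrogen. With every measured compound at a limit, the step from compound 1 to compound 4 is expected to be a number no higher from compound 1 to compound 4 (the limit leaves the size open), none beyond the scatter. Compound 4 is accordingly estimated at 100000 nM, most likely reported as a limit, within a range from 50000 nM to 200000 nM.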

Compound 4, half-maximal cytotoxic concentration: > 100000 nM
Compound 4 gave a limit, no number (the forecaster's own chance of this, stated with the estimate: 85%); the middle value sits exactly at the limit.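

Going by these compounds alone, compound 1 and compound 4 are both known in this assay only as limits of the assay, and no step between them can be read. The compounds shown leave open at what concentration any of them stops being tolerated, and whether hydrogen in place of cyclohexyl on an aromatic nitrogen alters that concentration.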